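Removing the Methoxy Group: Cytotoxicity of Compound 4

The source may hold more compounds than are shown below. What is called first, only, known or untested is meant among the compounds shown, and "the series" means these compounds.

Measured compounds and their values in an ADME assay on MT4 cells (Homo sapiens) for cytotoxicity, read by spectrophotometry, with a stated time of 5 days; on this read-out lower numbers stand for higher toxicity in this test and higher numbers for lower toxicity in this test:
Compound 1 `COc1ccc(N2CCN(CN3C(=O)/C(=N\NC(=S)NO)c4cc(F)ccc43)CC2)cc1` — 260000 nM
Compound 2 `CCn1cc(C(=O)O)c(=O)c2cc(F)c(N3CCN(CN4C(=O)/C(=N\NC(=S)NO)c5cc(C)ccc54)C(C)C3)c(F)c21` — 244000 nM
Compound 3 `CONC(=S)N/N=C1\C(=O)N(CN2CCN(c3ccc(OC)cc3)CC2)c2ccc(F)cc21` — 276000 nM

Compound 1 stands second highest of the three numbers measured in this assay. Its nearest neighbour is compound 3, which lies a 1.1-fold higher number from compound 1 to compound 3 (0.03 log units; within the scatter), and the step was within the scatter. Compound 2 is the furthest, yet its value and that of compound 1 are also within the scatter of each other, so the three measured compounds cannot be set in any order on this read-out.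

The unmeasured compound 4 `O=C1/C(=N\NC(=S)NO)c2cc(F)ccc2N1CN1CCN(c2ccccc2)CC1` differs from compound 1 by hydrogen in place of methoxy on an aromatic carbon. For the measured compounds named here, the only measured step that touches this part of the molecule is the one from compound 1 to compound 3, which alters the same oxygen and gave a difference within the scatter. Going by the values given here, no measured step removes the methoxy group outright, so there is no direct precedent for this change. Given that the one nearby step was flat, compound 4 is expected to show no step beyond the scatter in this assay, namely no change at the digits printed from compound 1 to compound 4 (within the scatter). Compound 4 is therefore estimated at 260000 nM, within a range of 130000 nM to 520000 nM.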

Compound 4, half-maximal cytotoxic concentration: 251000 nM
Compound 4: the middle estimate sits 1.0-fold (0.02 log units) above what was measured; the range from low to high includes it.
By their numbers in this assay, from the lowest: compounds 2, 4, 1 and 3 (each within the scatter of the next).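

For the compounds shown here, this is the first step in the set that acts on the aromatic ring at the far end of the piperazine side chain, and it replaces 4-methoxyphenyl with phenyl in this assay: a 1.0-fold lower number from compound 1 to compound 4 (0.02 log units; within the scatter). The earlier step, a 1.1-fold higher number from compound 1 to compound 3 (0.03 log units; within the scatter), placed a methyl on a different oxygen, so it said nothing about this ring, whereas the new pair shows that the methoxy group, para to a large group, can leave with a difference no larger than the scatter on this read-out. No supporting measurement is available to explain why this change leaves the number within the scatter.

The compounds shown leave open whether a different group on this same aromatic carbon, such as an amine, a carboxylic acid or a longer chain like butoxy, would move the number beyond the scatter. They also leave open whether phenyl in place of 4-methoxyphenyl would read the same in the setting of compound 3, where methyl sits on the other oxygen.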